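Swapping one aromatic group on compound 3

The source may hold more compounds than are shown below. What is called first, only, known or untested is meant among the compounds shown, and "the series" means these compounds.

In a functional assay on U-87MG ATCC cells for antiproliferative activity against U-87 MG (Homo sapiens), read by MTT assay, with a stated time of 48 h (on this read-out lower numbers stand for stronger inhibition and higher numbers for weaker inhibition), three compounds have been measured:
Compound 1 `COc1ccc(-c2nc(SCC(=O)c3sc(-c4ccccc4)nc3C)[nH]c(=O)c2C#N)cc1` gives 48400 nM
Compound 2 `COc1ccc(-c2nc(C)c(C(=O)CSc3nc(-c4ccc(OC)cc4)c(C#N)c(=O)[nH]3)s2)cc1` gives 25300 nM
Compound 3 `Cc1nc(-c2ccc(Cl)cc2)sc1C(=O)CSc1nc(-c2cccc(Cl)c2)c(C#N)c(=O)[nH]1` gives 40100 nM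

These three values lie within the usual scatter of one another, so compound 3 cannot be ranked against compound 1 or compound 2. Compound 4 `COc1ccc(-c2nc(SCC(=O)c3sc(-c4ccc(Cl)cc4)nc3C)[nH]c(=O)c2C#N)cc1` differs from compound 3 in one place (4-methoxyphenyl in place of 3-chlorophenyl on an aromatic carbon), where 4-methoxyphenyl stands in place of 3-chlorophenyl on an aromatic carbon, ortho to a cyano group.

Within the data shown here, no measured step makes this exact swap. The closest evidence is a 1.9-fold lower number from compound 1 to compound 2 (0.28 log units; within the scatter), which adds a methoxy in place of hydrogen on a different aromatic ring. Compound 1 and compound 2 already carry the entering 4-methoxyphenyl group, yet their values stay within the scatter of compound 3. No step beyond the scatter is therefore expected in this assay. The expected change is a 1.1-fold lower number from compound 3 to compound 4 (0.05 log units; within the scatter) and is small. Compound 4 is expected at 36000 nM in a range from 18000 nM to 70000 nM on this read-out.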

Compound 4, half-maximal inhibitory concentration: 35500 nM
For compound 4 the middle estimate is 1.0-fold (0.01 log units) above the measured one, and the stated range covers the measured number.
By their numbers in this assay, from the lowest: compounds 2, 4, 3 and 1 (each within the scatter of the next).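

In this assay, the direct exchange at the aromatic carbon ortho to a cyano group gives a 1.1-fold lower number from compound 3 to compound 4 (0.05 log units; within the scatter), so 4-methoxyphenyl and 3-chlorophenyl cannot be told apart at this position, despite their different substituents. The two other new steps concern a different aromatic ring: chloro in place of methoxy gives a 1.4-fold higher number from compound 2 to compound 4 (0.15 log units; within the scatter), and chloro in place of hydrogen gives a 1.4-fold lower number from compound 1 to compound 4 (0.13 log units; within the scatter), so neither change separates the compounds either. No measurement available here offers an explanation for these results.

Among these compounds, only two substituted phenyl groups appear at this position, so these results say little about groups of a different kind. Going by these compounds, whether an amine, a carboxylic acid or a longer chain there would shift the number beyond the scatter remains open.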